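Fluorine Added to the Aniline Ring of a Quinazoline Series

The source may report more compounds than this note shows. Statements on the series, on what has been measured and on what is new or still open speak of the compounds shown alone.

Measured compounds:
- compound 1, `CCS(=O)(=O)Nc1cc(-c2ccc3ncnc(Nc4ccc(F)cc4)c3c2)cnc1OC`: 1470 nM
- compound 2, `CCS(=O)(=O)Nc1cc(-c2ccc3ncnc(Nc4ccc(F)cc4F)c3c2)cnc1OC`: 2490 nM
- compound 3, `CCS(=O)(=O)Nc1cc(-c2ccc3ncnc(Nc4cccc(C(=O)OC)c4)c3c2)cnc1OC`: 2400 nM

All three compounds were tested in a functional assay on SK-HEP1 cells (Homo sapiens) for cytotoxicity, read by sulforhodamine B assay, with a stated time of 72 h; on this read-out higher numbers stand for weaker inhibition and lower numbers for stronger inhibition. The three values lie close together, and none of the steps between them reaches beyond the usual scatter of this assay.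

Compound 1 and compound 2 differ in one place: fluoro in place of hydrogen on an aromatic carbon. This change gave a 1.7-fold higher number from compound 1 to compound 2 (0.23 log units; within the scatter).

Compound 3 carries a different group on the shared core; the difference from compound 1 is 3-(methoxycarbonyl)phenyl in place of 4-fluorophenyl on a nitrogen on an aromatic ring, and it gave a 1.6-fold higher number from compound 1 to compound 3 (0.21 log units; within the scatter). Between compound 2 and compound 3 the change is 3-(methoxycarbonyl)phenyl in place of 2,4-difluorophenyl on a nitrogen on an aromatic ring, with a 1.0-fold lower number from compound 2 to compound 3 (0.02 log units; within the scatter).

Compound 4, `CCS(=O)(=O)Nc1cc(-c2ccc3ncnc(Nc4ccc(F)c(C(=O)OC)c4)c3c2)cnc1OC`, has not yet been measured in this assay. It differs from compound 3 in one place: fluoro in place of hydrogen on an aromatic carbon. This is the same kind of change as that from compound 1 to compound 2, but the surroundings differ: in compound 2 the new fluoro sits ortho to a large group and meta to a fluoro group, whereas in compound 4 it sits ortho to a methoxycarbonyl group and para to a large group.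

Since compound 1 to compound 2 gave a 1.7-fold higher number from compound 1 to compound 2 (0.23 log units; within the scatter), a step of similar size is expected here, namely a 1.3-fold higher number from compound 3 to compound 4 (0.10 log units; within the scatter). Compound 4 is therefore estimated at 3000 nM in this assay, with a range from 1500 nM to 6500 nM.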

Compound 4, half-maximal inhibitory concentration: 5180 nM
Compound 4: the middle estimate sits 1.7-fold (0.24 log units) below what was measured, within the range that was stated.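

In this assay, fluoro in place of hydrogen on the ring that carries the methoxycarbonyl group gave a 2.2-fold higher number from compound 3 to compound 4 (0.33 log units; beyond the scatter), and set beside the earlier fluoro step, the two do not differ: the same change on two cores in this assay, a 1.7-fold higher number (0.23 log units; within the scatter) from compound 1 to compound 2 and a 2.2-fold higher number (0.33 log units; beyond the scatter) from compound 3 to compound 4, 1.3-fold (0.11 log units) apart, within the scatter of two such steps. Two further modest steps end at the same compound, a 3.5-fold higher number from compound 1 to compound 4 (0.55 log units; beyond the scatter) for the added methoxycarbonyl group and a 2.1-fold higher number from compound 2 to compound 4 (0.32 log units; beyond the scatter) for 4-fluoro-3-(methoxycarbonyl)phenyl in place of 2,4-difluorophenyl. So the fluoro change carried from one core to the other with no detectable difference in the size of its step, but this rests on only two pairs, one of them within the scatter, with the fluoro in different surroundings in each, and it gives neither a general rule for the series nor a reason for the shift.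

The compounds shown leave open whether a chloro group in place of the fluoro, or a carboxylic acid or an amide in place of the methoxycarbonyl group, would give steps of similar size. They also leave open whether the fluoro step would hold on a ring carrying an amine, or on cells other than those used here.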